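The compounds below may be only part of what the source reports. "The series", "measured", "known", "first", "only" and "open" are said of these compounds alone.

Of the compounds shown here, three have been measured in a physicochemical assay, with a stated time of 180 min, tested at 0.5 mg/mL; a higher number here means more inhibition at the concentration tested (going by the name of the read-out), a lower number less inhibition. Compound 1 `CC(C)COC(=O)Nc1ccc([Se][Se]c2ccc(NC(=O)OCC(C)C)cc2)cc1` gives 66.5%, compound 2 `O=C(Nc1ccc([Se][Se]c2ccc(NC(=O)OCc3ccccc3)cc2)cc1)OCc1ccccc1` gives 7.4%, and compound 3 `CC(C)COC(=O)Nc1ccc([Se]C#N)cc1` gives 27.1%. Compound 3 thus stands second highest of the three, with compound 2 nearest and lower by a margin beyond the usual scatter, and compound 1 furthest and higher by a margin also beyond the scatter. Compound 4 `N#C[Se]c1ccc(NC(=O)Oc2ccccc2)cc1` has not been measured. It differs from compound 3 by a single change: phenyl in place of isobutyl on an oxygen next to a carbonyl group. Going by the values given here, no measured pair shows this change on the shared core, but compound 1 and compound 2 show a lower number once an aromatic group replaces isobutyl on an oxygen next to a carbonyl group. A downward step is therefore expected, estimated as a number 14.1 percentage points lower from compound 3 to compound 4 (beyond the scatter) in this assay. Compound 4 is expected to give about 13%, within 3% to 30%.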

Compound 4, a percentage reported as inhibition, at one concentration (the size of the read-out at that concentration, not a potency): 19.3%
Estimate against measurement, compound 4: 6.3 percentage points below, within the range that was stated.
By their numbers in this assay, from the lowest: compound 2; then compounds 4 and 3 (each within the scatter of the next); then compound 1.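

Phenyl in place of isobutyl on an oxygen next to a carbonyl group amounts in this assay to a number 7.8 percentage points lower from compound 3 to compound 4 (within the scatter). Going by these compounds alone, this is the first pair here that differs in this one place, and on the shared core the change leaves no difference that can be told from scatter. Nothing measured here speaks to a reason for this result. Still open, going by these compounds, is whether a longer chain such as hexyl in this place would also stay within the scatter of compound 3. Also open, on these data alone, is whether an amine on the phenyl of compound 4 would shift the number.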